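The compounds below may be only part of what the source reports. "The series", "measured", "known", "first", "only" and "open" are said of these compounds alone.

Measured compounds:
compound 1 `CC(C)N(Cc1cccc(OCCCCCC(=O)O)c1)C(=O)c1ccc(-c2cc3ccccc3n2S(=O)(=O)c2ccccc2)cc1` — > 26000 nM
compound 2 `CCOC(=O)CCCCCOc1cccc(CN(C(=O)c2ccc(-c3ccc(C(C)=O)s3)cc2)C(C)C)c1` — > 26000 nM

Working notes on the series. In an ADME assay on HEK293 cells (Homo sapiens) for cytotoxicity, read by CellTiter-Glo and resazurin assay, with a stated time of 72 h (on this read-out higher numbers stand for an effect only at larger amounts of compound and lower numbers for an effect already at smaller amounts), compound 1 gives > 26000 nM, which is a limit of the assay and not a number. In this assay compound 2 likewise gives > 26000 nM, again a limit and not a number. So compound 2 stands exactly where the only other measured compound stands: the limit of > 26000 nM in this assay, at which 2 of the 2 values shown sit. For the measured compounds named here, no pair of measured compounds differing in one place exists, so no measured step can be stated, and nothing beyond the fact that both values sit at the limit can be read from the pair.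

Compound 3 `CCOC(=O)CCCCCOc1cccc(CN(C(=O)c2ccc(-c3cccc(Cl)c3)cc2)C(C)C)c1` is still to be measured in this assay. It differs from compound 2 by 3-chlorophenyl in place of 5-acetylthiophen-2-yl on an aromatic carbon. With both measured values at the limit, no basis exists for expecting a step in either direction beyond the scatter. The expected step is therefore a step that the limit leaves unreadable from compound 2 to compound 3, that is none beyond the scatter. Compound 3 is estimated at 30000 nM in this assay, with a range from 13000 nM to 70000 nM, most likely reported again only as a limit.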

Compound 3, half-maximal effective concentration: > 18400 nM
Compound 3 gave a limit, no number (the forecaster's own chance of this, stated with the estimate: 80%); the middle value lies beyond the limit too.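

In this assay compound 3 gives > 18400 nM, which is a limit and not a number. Compound 2 gives > 26000 nM, again a limit and not a number. The step between compound 2 and compound 3 therefore cannot be read. The compounds shown leave open at what concentration any of them reaches a half-maximal effect in this assay, and whether 3-chlorophenyl in place of 5-acetylthiophen-2-yl changes it.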